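A few compounds are considered here, and "the series" means these few. Any claim that something is new, unique, unknown or untested is made for them only; others in the source may bear on it.

The series shares one core, seen in compound 1 `CCc1ccc2oc(CSc3nnc(CNc4ccccc4)n3CC)nc2c1`, compound 2 `CC/C(=N/OC)c1ccc2oc(CSc3nnc(CNc4ccccc4)n3CC)nc2c1` and compound 3 `CCC(O)c1ccc2oc(CSc3nnc(CNc4ccccc4)n3CC)nc2c1`. In an assay on isolated protein for inhibition of long-chain fatty acid transport protein 1 (Mus musculus) (on this read-out higher numbers stand for weaker inhibition and lower numbers for stronger inhibition), compound 1 gives 1800 nM and compound 3 gives 3700 nM, so compound 3 holds the higher of the two numbers. Compound 2 reaches only a limit of the method, > 10000 nM. The supporting line here is the limit of > 10000 nM in this assay, at which 1 of the 3 values shown sits. Compound 4 `CCn1c(CNc2ccccc2)nnc1SCc1nc2cc(Cl)ccc2o1` is not yet measured; it differs from compound 3 by chloro in place of 1-hydroxypropyl on an aromatic carbon. For the measured compounds named here, the steps that bear on this are a 2.1-fold higher number from compound 1 to compound 3 (0.31 log units; beyond the scatter), where the 1-hydroxypropyl entered, and an at least 5.5-fold higher number from compound 1 to compound 2 (0.74 log units; beyond the scatter). Removing the 1-hydroxypropyl is expected to undo that earlier rise, giving a modest fall, a 2.5-fold lower number from compound 3 to compound 4 (0.39 log units; beyond the scatter). Compound 4 is therefore estimated at 1500 nM, within 600 nM to 4000 nM.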

Compound 4, half-maximal inhibitory concentration: 2300 nM
Compound 4: middle estimate off by 1.5-fold (0.19 log units), on the low side; the range from low to high includes it.
By their numbers in this assay, from the lowest: compounds 1, 4 and 3 (each within the scatter of the next, the first and the last beyond it). At a limit, above all of these: compound 2.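

In this assay chloro, a single heavy atom with no hydrogen-bond donor or acceptor, cannot be told apart from either earlier small group at this aromatic carbon: a 1.3-fold higher number from compound 1 to compound 4 (0.11 log units; within the scatter) and a 1.6-fold lower number from compound 3 to compound 4 (0.21 log units; within the scatter) both lie within the scatter. Compound 2 gives > 10000 nM as a limit of the method. The step of an at least 4.3-fold lower number from compound 2 to compound 4 (0.63 log units; beyond the scatter) is therefore only a bound, and of the groups shown only the one with 6 heavy atoms stands apart from chloro.

Still open, on these data alone, is whether an amine, a carboxylic acid or a longer chain at this position would give a number clearly below that of compound 1 in this assay or would raise it further.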